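A few compounds are considered here, and "the series" means these few. Any claim that something is new, unique, unknown or untested is made for them only; others in the source may bear on it.

Working notes on the series.

Three compounds share one core and have been run in a physicochemical assay for solubility, with a stated time of 18 h, at pH 7.4; on this read-out lower numbers stand for lower solubility and higher numbers for higher solubility. Compound 1 `COc1ccc(F)cc1CNCCCNc1ccnc2cc(-c3ccccc3)ccc12` gives 32000 nM. Compound 2 `COc1ccc(F)cc1CNCCCNc1ccnc2cc(Oc3ccc(F)cc3)ccc12` gives 14500 nM. Compound 3 `COc1ccc(F)cc1CNCCCNc1ccnc2cc(CC3CCCCC3)ccc12` gives 4200 nM, the lowest of the three numbers; its nearest neighbour is compound 2 and its furthest is compound 1, both beyond the scatter.

The steps among the measured compounds: a 2.2-fold lower number from compound 1 to compound 2 (0.34 log units; beyond the scatter); a 7.6-fold lower number from compound 1 to compound 3 (0.88 log units; beyond the scatter); a 3.5-fold lower number from compound 2 to compound 3 (0.54 log units; beyond the scatter). All three are modest and all point the same way, with the saturated ring of compound 3 giving the lowest reading.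

Compound 4 `COc1ccc(F)cc1CNCCCNc1ccnc2cc(Cc3cccc(C(F)(F)F)c3)ccc12` is not yet measured. The change from compound 3 is 3-(trifluoromethyl)phenyl in place of cyclohexyl on a saturated chain carbon bound to an aromatic carbon. For the measured compounds named here, the step from compound 1 to compound 3 bears on it most closely, since it swaps an aromatic ring for a saturated one at the same part of the molecule, and compound 4 returns an aromatic ring at that position; the trifluoromethyl on it has no precedent among the measured compounds, so its contribution is unknown. An expected step that partly reverses a 7.6-fold lower number from compound 1 to compound 3 (0.88 log units; beyond the scatter) seems reasonable, though with the trifluoromethyl uncounted the size is uncertain. Compound 4 is expected to show a 1.4-fold higher number from compound 3 to compound 4 (0.15 log units; within the scatter) in this assay. The estimate for compound 4 is 6000 nM, with a range from 2000 nM to 18000 nM.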

Compound 4, solubility: 4200 nM
Estimate against measurement, compound 4: 1.4-fold (0.15 log units) above; measured number inside the range.
By their numbers in this assay, from the lowest: compounds 3 and 4 (each within the scatter of the next); then compound 2; then compound 1.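

In this assay, 3-(trifluoromethyl)phenyl in place of cyclohexyl on a saturated chain carbon bound to an aromatic carbon gives no change at the digits printed from compound 3 to compound 4 (within the scatter), so at this position an aromatic ring carrying trifluoromethyl and a saturated ring of carbon only cannot be told apart on this read-out. The distance to the other two compounds holds at a 3.5-fold lower number from compound 2 to compound 4 (0.54 log units; beyond the scatter) and a 7.6-fold lower number from compound 1 to compound 4 (0.88 log units; beyond the scatter), which shows that having an aromatic ring in this part of the molecule does not by itself keep the number near those of compound 1 and compound 2. No measurement at hand accounts for this outcome, and the series offers no explanation of it.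

The swap changes the ring and adds the trifluoromethyl in one step, and the compounds shown do not divide the outcome between the two: the plain benzyl group would be the direct comparison. Also open, going by these compounds, is whether an amine or a carboxylic acid in place of the trifluoromethyl would move the number away from that of compound 4 in this assay.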